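The source may hold more compounds than are shown below. What is called first, only, known or untested is meant among the compounds shown, and "the series" means these compounds.

- compound 1 `CC(=O)NS(=O)(=O)CCc1cn(-c2ccc(Br)cc2)nc1-c1ccc(Cl)cc1` reads 165000 nM
- compound 2 `CS(=O)(=O)NC(=O)/C=C/c1cn(-c2ccc(Br)cc2)nc1-c1ccncc1` reads 115000 nM

Going by the values given here, in a physicochemical assay for solubility, in phosphate buffer, measured as thermodynamic solubility, at pH 7.4 (a higher number here means a more soluble compound, a lower number a less soluble compound), these two compounds stand within the usual scatter of each other, so compound 1 sits level with the only other number available. Compound 3 `Clc1ccc(-c2nn(-c3ccc(Br)cc3)cc2CCc2nnn[nH]2)cc1` differs from compound 1 by one change (1H-tetrazol-5-yl in place of acetylsulfamoyl on a saturated chain carbon, two bonds along the chain from an aromatic carbon), with 1H-tetrazol-5-yl in place of acetylsulfamoyl. Among the compounds with values here, no measured step between close pairs exists to guide the expectation. The expected step is small and slightly downward (a 1.4-fold lower number from compound 1 to compound 3 (0.14 log units; within the scatter)), not beyond the scatter. For compound 3 the estimated value is 120000 nM, with an expected range from 40000 nM to 300000 nM.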

Compound 3, solubility: 150000 nM
Estimate against measurement, compound 3: 1.3-fold (0.10 log units) below; the range from low to high includes it.
By their numbers in this assay, from the lowest: compounds 2, 3 and 1 (each within the scatter of the next).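

In this assay, going by these compounds alone, putting 1H-tetrazol-5-yl in place of acetylsulfamoyl on a saturated chain carbon, two bonds along the chain from an aromatic carbon, gives a 1.1-fold lower number from compound 1 to compound 3 (0.04 log units; within the scatter) and provides the first step between close compounds. At this position, a group with no ring and a five-membered aromatic ring with 4 hetero atoms therefore read level. No measured evidence accounts for this result.

Open, going by these compounds, is whether a carboxylic acid or an amine at this place would also read level with compound 1. Also open, on these data alone, is whether 1H-tetrazol-5-yl on a longer chain would stay level with compound 3.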